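Benzoxaborole series: chloro addition on the benzoyl ring

The source may report more compounds than this note shows. Statements on the series, on what has been measured and on what is new or still open speak of the compounds shown alone.

Measured so far:
compound 1 `OB1OCc2ccc(-n3cc(Sc4ccc(O)cc4)c4ccccc43)cc21`: > 10 ug/mL
compound 2 `COc1ccc(CNC(=O)c2cccn2-c2ccc3c(c2)B(O)OC3)cc1`: > 10 ug/mL
compound 3 `O=C(c1ccccc1)c1ccn(-c2ccc3c(c2)B(O)OC3)c1`: > 10 ug/mL

In an ADME assay on L929 cells (Mus musculus) for cytotoxicity, read by resazurin assay, with a stated time of 72 h (a higher number here means a weaker inhibitor, a lower number a stronger inhibitor), compound 1 gives only a limit, > 10 ug/mL. In this assay compound 2 likewise gives only a limit, > 10 ug/mL. Compound 3 sits at the same limit, > 10 ug/mL, and no number below it is known. Nothing distinguishes the three on these readings, because of the limit of > 10 ug/mL in this assay, at which 3 of the 3 values shown sit.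

Compound 4 `O=C(c1cccc(Cl)c1)c1ccn(-c2ccc3c(c2)B(O)OC3)c1` differs from compound 3 in one place: chloro in place of hydrogen on an aromatic carbon. Among the compounds with values here, no measured pair with this difference exists. With all three known values at the limit, there is no basis for a direction; the expected step is a step that the limit leaves unreadable from compound 3 to compound 4, none beyond the scatter, and the most probable outcome is again a limit rather than a number. Compound 4 is therefore estimated at 15 ug/mL, with a range from 5 ug/mL to 50 ug/mL.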

Compound 4, half-maximal inhibitory concentration: > 10 ug/mL
Compound 4 ended at the assay's limit; the forecaster's own chance of this, stated with the estimate: 80%; the middle value lies beyond the limit too.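

No step can be read between compound 3 and compound 4 in this assay, because both values are limits: the limit of > 10 ug/mL in this assay, at which 4 of the 4 values shown sit.

The compounds shown leave open whether chloro in place of hydrogen changes the reading at all, and how the four compare with one another in this assay.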